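Swapping a fluoro for a methoxy on the pyridine ring

The compounds below may be only part of what the source reports. "The series", "measured", "known", "first", "only" and "open" are said of these compounds alone.

Three compounds share one core and were measured in an in vitro functional assay on HEK285-7 cells for antagonist activity at prostaglandin D2 receptor 2 (Homo sapiens), read by BRET and beta-arrestin recruitment; a higher number here means a weaker inhibitor, a lower number a stronger inhibitor. Compound 1 `O=C(O)Cc1sc(C(c2ccc(F)cc2)c2ccc(F)cc2)nc1-c1cccc(F)c1` gives 18 nM. Compound 2 `CS(=O)(=O)Nc1cccc(-c2nc(C(c3ccc(F)cc3)c3ccc(F)cc3)sc2CC(=O)O)c1` gives 370 nM, and compound 3 `O=C(O)Cc1sc(C(c2ccc(F)cc2)c2ccc(F)cc2)nc1-c1ccnc(F)c1` gives 4.7 nM, the lowest of the three numbers and thus the strongest inhibitor so far; the two steps that lead to it are a 3.8-fold lower number from compound 1 to compound 3 (0.58 log units; beyond the scatter) and a 79-fold lower number from compound 2 to compound 3 (1.90 log units; beyond the scatter).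

Compound 4 `COc1cc(-c2nc(C(c3ccc(F)cc3)c3ccc(F)cc3)sc2CC(=O)O)ccn1` is the next step from compound 3: methoxy in place of fluoro on an aromatic carbon. The measured steps touch this only loosely. Replacing fluoro with a larger methanesulfonamido gave a 21-fold higher number from compound 1 to compound 2 (1.31 log units; beyond the scatter), while changing the ring itself gave a 3.8-fold lower number from compound 1 to compound 3 (0.58 log units; beyond the scatter). A methoxy is far smaller than a methanesulfonamido, so the former step is a distant guide at best. The expectation is therefore a small step in this assay, likely within or just beyond the scatter, in the weaker direction.

Compound 4 is estimated at 8 nM, with a range from 3 nM to 25 nM, meaning an expected step of a 1.7-fold higher number from compound 3 to compound 4 (0.23 log units; within the scatter).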

Compound 4, half-maximal inhibitory concentration: 380 nM
For compound 4 the middle estimate is 48-fold (1.68 log units) below the measured one; measured number above the stated range.
By their numbers in this assay, from the lowest: compound 3; then compound 1; then compounds 2 and 4 (each within the scatter of the next).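

In this assay, methoxy in place of fluoro on this carbon next to the ring nitrogen gives an 81-fold higher number from compound 3 to compound 4 (1.91 log units; beyond the scatter) even though the group grows only from 1 heavy atom to 2, so a very small edit at this position can have a large effect. The change also more than cancels the gain seen with the pyridine ring, as the 2-methoxypyridin-4-yl group in place of 3-fluorophenyl gives a 21-fold higher number from compound 1 to compound 4 (1.32 log units; beyond the scatter) and the comparison with the methanesulfonamido compound gives a 1.0-fold higher number from compound 2 to compound 4 (0.01 log units; within the scatter) so that these two cannot be told apart. Nothing in the available data explains the size of this loss.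

On these data alone, whether a methyl, a chloro or an amine on this same carbon would stay close to compound 3 or fall with compound 4 remains open. So does the question of whether a methoxy on the phenyl ring of compound 1 would carry a similar cost.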